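Benzylamino in place of arylthio on the shared core

The source may report more compounds than this note shows. Statements on the series, on what has been measured and on what is new or still open speak of the compounds shown alone.

Measured so far:
- Compound 1 `Nc1cc(N)c2nc(-c3ccccc3)c(Sc3ccc(F)cc3)nc2c1`: in a functional assay on Hs-578T cells (Homo sapiens) for inhibition, read by sulforhodamine B assay, with a stated time of 48 h (on this read-out higher numbers stand for weaker inhibition of growth and lower numbers for stronger inhibition of growth), compound 1 gives 26900 nM.
- Compound 2 `COc1cc(CNc2nc3cc(N)cc(N)c3nc2-c2ccccc2)cc(OC)c1OC`: in this assay compound 2 gives 3020 nM.
- Compound 3 `CCOC(=O)[C@H](CCC(=O)O)NC(=O)c1ccc(CNc2nc3cc(N)cc(N)c3nc2-c2ccccc2)cc1`: in this assay compound 3 reaches only < 100000 nM, which is a limit of the assay and not a number.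

Three compounds share the same core and differ only in the group attached to it. Of the two numbers actually measured, compound 1 stands highest, and compound 2 lies well below it, a gap beyond the usual scatter of this kind of measurement. Compound 3 sits at the limit of < 100000 nM in this assay, at which 1 of the 3 values shown sits, so it adds no number to compare.

The step under consideration leads from compound 1 to compound 4 `Nc1cc(N)c2nc(-c3ccccc3)c(NCc3ccc(F)cc3)nc2c1`, which has not yet been measured. The change is (4-fluorobenzyl)amino in place of (4-fluorophenyl)sulfanyl on an aromatic carbon. Compound 2 also carries a benzylamino group on the same core and gives a clearly lower number than compound 1, though with different substituents on its benzyl ring. On that ground a move toward stronger inhibition of growth is expected for compound 4, smaller than the gap that compound 2 shows. The expected step is estimated as a 3.4-fold lower number from compound 1 to compound 4 (0.53 log units; beyond the scatter). Compound 4 is therefore estimated at 8000 nM, within a range from 2000 nM to 30000 nM.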

Compound 4, concentration for 50% growth inhibition: 4900 nM
Compound 4: middle estimate off by 1.6-fold (0.21 log units), on the high side; the range from low to high includes it.
By their numbers in this assay, from the lowest: compounds 2 and 4 (each within the scatter of the next); then compound 1.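

In this assay the exchange of (4-fluorophenyl)sulfanyl for (4-fluorobenzyl)amino gives a 5.5-fold lower number from compound 1 to compound 4 (0.74 log units; beyond the scatter) while the fluorine-bearing ring stays the same. This is the first pair shown that differs in one place only, so the lower number seen with a benzylamino group no longer rests on compound 2 alone, whose benzyl ring carries other substituents. The aromatic carbon next to the ring nitrogen therefore responds to the group attached to it, but nothing measured here says why the number moves.

The step swaps the sulfur for a nitrogen and also adds a carbon to the link, so the compounds shown leave open which of these two differences accounts for it; a (4-fluorophenyl)amino group, with the nitrogen but without the added carbon, and a (4-fluorobenzyl)sulfanyl group, with the added carbon but keeping the sulfur, would pull them apart. Also open, as far as these compounds go, is whether the amine hydrogen matters, which an N-methyl-N-(4-fluorobenzyl)amino group at the same carbon would address.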